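Furan-3-yl in place of furan-2-yl on the amide carbonyl

The source may hold more compounds than are shown below. What is called first, only, known or untested is meant among the compounds shown, and "the series" means these compounds.

In a functional assay on HCT-116 cells (Homo sapiens) for inhibition, read by colorimetric assay and sulforhodamine B assay, with a stated time of 48 h (on this read-out higher numbers stand for weaker inhibition of growth and lower numbers for stronger inhibition of growth), compound 2 `CCCCCCCCCCCC[C@@H](O)[C@H]1CC[C@H]([C@H](O)CCCCCCCCCCNC(=O)c2ccco2)O1` gives 7760 nM, the higher of the two numbers, and compound 1 `CCCCCCCCCCCC[C@@H](O)[C@H]1CC[C@H]([C@H](O)CCCCCCCCCCNC(=O)c2cccs2)O1` gives 1290 nM. Compound 3 `CCCCCCCCCCCC[C@@H](O)[C@H]1CC[C@H]([C@H](O)CCCCCCCCCCNC(=O)c2ccoc2)O1` is still unmeasured and differs from compound 2 as follows: furan-3-yl in place of furan-2-yl on a carbonyl carbon. Within the data shown here, the only measured step is a 6.0-fold higher number from compound 1 to compound 2 (0.78 log units; beyond the scatter). It replaces thiophen-2-yl with furan-2-yl, a different change, so it bears only indirectly and gives an upper guide to size. Among the measured compounds shown here, no measured step covers the furan-3-yl change itself. The expected step, slightly downward and within the scatter, is a 1.6-fold lower number from compound 2 to compound 3 (0.19 log units; within the scatter). For compound 3 the estimated value is 5000 nM, with an expected range of 2000 nM to 12000 nM.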

Compound 3, concentration for 50% growth inhibition: 3470 nM
For compound 3 the middle estimate is 1.4-fold (0.16 log units) above the measured one, within the range that was stated.
By their numbers in this assay, from the lowest: compound 1; then compound 3; then compound 2.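

In this assay the attachment point of the furan matters on its own: with the same atoms, the step is a 2.2-fold lower number from compound 2 to compound 3 (0.35 log units; beyond the scatter) and lies beyond the scatter. Furan-3-yl does not recover the thiophen-2-yl number either, leaving a 2.7-fold higher number from compound 1 to compound 3 (0.43 log units; beyond the scatter) as the remaining gap. Nothing available accounts for this order.

From the compounds shown here alone, whether thiophen-3-yl would shift in the same direction as the furan pair remains open. So does how phenyl or pyridin-3-yl on the same carbonyl carbon would rank against these three compounds.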